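Solubility notes: methyl in place of pyridin-3-yl

The source may hold more compounds than are shown below. What is called first, only, known or untested is meant among the compounds shown, and "the series" means these compounds.

In a physicochemical assay for solubility, at pH 6.8 (on this read-out higher numbers stand for higher solubility and lower numbers for lower solubility), compound 1 `Cc1c(COCCCCO)[nH]c2ccccc2c1=O` reports >= 100000 nM, a limit of the assay rather than a number. Compound 2 `Cc1c(COc2cccc(OCC3CCOCC3)c2)[nH]c2ccc(-c3cccnc3)cc2c1=O` reports in this assay < 1000 nM, again a limit and not a number. Compound 2 therefore sits at the limit of < 1000 nM in this assay, at which 1 of the 2 values shown sits. Compound 1 sits at the limit of >= 100000 nM in this assay, at which 1 of the 2 values shown sits. Compound 3 `Cc1ccc2[nH]c(COc3cccc(OCC4CCOCC4)c3)c(C)c(=O)c2c1` differs from compound 2 by methyl in place of pyridin-3-yl on an aromatic carbon. Within the data shown here, no measured step joins two compounds in this set, so the size of this change is open; the expected step is a step that the limit leaves unreadable from compound 2 to compound 3, not beyond the scatter, with compound 3 likely staying at the limit. The expected solubility of compound 3 is 700 nM, between 200 nM and 3000 nM.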

Compound 3, solubility: < 1000 nM
Compound 3: a limit, no number (the forecaster's own chance of this, stated with the estimate: 65%); the middle value is on the limit's open side.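

Among these compounds, compound 2 and compound 3 both sit at a limit in this assay, so no step between them can be read. The compounds shown leave open where either true value lies, and whether methyl in place of pyridin-3-yl shifts the read-out at all.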